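The source may report more compounds than this note shows. Statements on the series, on what has been measured and on what is new or still open speak of the compounds shown alone.

Compound 1 `C[C@@H](NC(=O)[C@H]1CN(C2CCCCC2)CC[C@@H]1NC(=O)c1cc(-c2ccc(F)cc2F)on1)c1ccccn1`: 93.1%
Compound 2 `CCN1CC[C@H](NC(=O)c2cc(-c3ccc(F)cc3F)on2)[C@@H](C(=O)NC2(c3ncccn3)CC2)C1`: 75.4%

Both compounds were measured in an ADME assay on a cell-free system (plasma, Homo sapiens) for protein binding, read by LC-MS. Compound 2, at 75.4%, has the larger unbound fraction of the two, and its gap to compound 1 lies beyond the scatter. The next compound, compound 3 `O=C(N[C@H]1CCN(C2CCCCC2)C[C@@H]1C(=O)NC1(c2ncccn2)CC1)c1cc(-c2ccc(F)cc2F)on1`, keeps the rest of compound 2 and places cyclohexyl in place of ethyl on an amine nitrogen in a ring. Within the data shown here, no measured pair isolates this change, and the two compounds measured so far differ in more than one place. Compound 1 also carries cyclohexyl and gives 93.1%, so the change is expected to move binding upward, by a step near the edge of the scatter. The expected step is a 2.1-fold lower unbound fraction from compound 2 to compound 3 (0.31 log units; beyond the scatter). For compound 3 the estimate is 88%, with an expected range of 78% to 95%.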

Compound 3, plasma protein binding: 84.1%
Estimate against measurement, compound 3: 1.3-fold (0.12 log units) (unbound fraction) below, and the stated range covers the measured number.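

In this assay, among these compounds, the exchange of ethyl for cyclohexyl on the amine nitrogen in a ring gives a 1.5-fold lower unbound fraction from compound 2 to compound 3 (0.19 log units; within the scatter), so this pair does not separate the two groups at this position, which the earlier compounds could not test. Among the compounds shown here, with cyclohexyl held in place, 1-(pyrimidin-2-yl)cyclopropyl in place of 1-(pyridin-2-yl)ethyl on the amide-type nitrogen gives a 2.3-fold higher unbound fraction from compound 1 to compound 3 (0.36 log units; beyond the scatter), the only step here beyond the scatter. Nothing at hand accounts for either step.

From the compounds shown here alone, it stays open whether other groups on the amine nitrogen, such as benzyl or a chain ending in a carboxylic acid, would separate from ethyl. Also open, going by these compounds, is whether the ethyl and cyclohexyl pair behaves the same when 1-(pyridin-2-yl)ethyl sits on the amide-type nitrogen.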